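Closing the dimethylaminomethyl chain of compound 1 into a ring

The source may hold more compounds than are shown below. What is called first, only, known or untested is meant among the compounds shown, and "the series" means these compounds.

Of the compounds shown here, three on a shared core have been measured in an assay on isolated protein for binding affinity to secreted frizzled-related protein 1 (Homo sapiens), read by fluorescence; a lower number here means a stronger inhibitor, a higher number a weaker inhibitor. Compound 1 `CN(C)CC(=O)N1CCC(NS(=O)(=O)c2cc(S(=O)(=O)c3ccccc3)ccc2C(F)(F)F)CC1` gives 300 nM, the highest of the three numbers. Compound 2 `CC(C)(C)OC(=O)N1CCC[C@@H]1C(=O)N1CCC(NS(=O)(=O)c2cc(S(=O)(=O)c3ccccc3)ccc2C(F)(F)F)CC1` gives 120 nM, and compound 3 `O=C([C@@H]1CCCN1C(=O)Nc1ccccc1)N1CCC(NS(=O)(=O)c2cc(S(=O)(=O)c3ccccc3)ccc2C(F)(F)F)CC1` gives 20 nM, the lowest of the set. Within the data shown here, the one single-point step among them is a 2.5-fold lower number from compound 1 to compound 2 (0.40 log units; beyond the scatter).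

Compound 4 `CN1CCC[C@H]1C(=O)N1CCC(NS(=O)(=O)c2cc(S(=O)(=O)c3ccccc3)ccc2C(F)(F)F)CC1` is the next compound. It differs from compound 1 in one place: 1-methylpyrrolidin-2-yl in place of (dimethylamino)methyl on a carbonyl carbon. The new group keeps a single hydrogen-bond acceptor and no donor, as the leaving group did, and adds one defined stereocentre.

Among the measured compounds shown here, only the step from compound 1 to compound 2 bears on this change, and only loosely: there the pyrrolidine ring also entered, but carrying a tert-butoxycarbonyl group instead of a methyl group, and it brought a modest improvement. Compound 3 shows that a larger substituent on that ring nitrogen can go further, yet nothing tells what a bare methyl does. A step in the same direction, somewhat smaller, is therefore expected, though one within the scatter cannot be excluded; the expected step is a 1.5-fold lower number from compound 1 to compound 4 (0.18 log units; within the scatter). For compound 4 the estimate in this assay is 200 nM, with a range from 70 nM to 600 nM.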

Compound 4, half-maximal inhibitory concentration: 120 nM
Estimate against measurement, compound 4: 1.7-fold (0.22 log units) above, and the stated range covers the measured number.
By their numbers in this assay, from the lowest: compound 3; then compounds 2 and 4 (each within the scatter of the next); then compound 1.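

In this assay, the 1-methylpyrrolidin-2-yl group on the carbonyl carbon gives a 2.5-fold lower number from compound 1 to compound 4 (0.40 log units; beyond the scatter), so a modest gain over the (dimethylamino)methyl group needs no tert-butoxycarbonyl on the ring nitrogen. Methyl and tert-butoxycarbonyl cannot be told apart at this position, with no change at the digits printed from compound 2 to compound 4 (within the scatter), while methyl in place of phenylcarbamoyl gives a 6.0-fold higher number from compound 3 to compound 4 (0.78 log units; beyond the scatter), which sets the phenylcarbamoyl group apart from methyl on that nitrogen. No evidence is at hand on what lies behind any of these steps.

The compounds shown do not separate the ring itself from the added carbon atoms, so an open chain such as a (diethylamino)methyl group could tell whether the step from the (dimethylamino)methyl group needs the ring at all. Also open, going by these compounds, are the mirror-image form of the 1-methylpyrrolidin-2-yl group and how a free ring amine, an acetyl group or a benzyl group on the ring nitrogen would compare with methyl and phenylcarbamoyl.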